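A Larger Thiocarbon-Free Name: One More Carbon on the Tail

The source may hold more compounds than are shown below. What is called first, only, known or untested is meant among the compounds shown, and "the series" means these compounds.

Compound 3 `N/C(S)=N/CCCCn1nc(-c2ccccc2)ccc1=O` is the reference point here. Within the data shown here, in a functional assay on the whole organism with Rattus norvegicus as the target, at a dose of 100 mg/kg (a higher number here means more inhibition at the dose given (going by the name of the read-out), a lower number less inhibition), compound 3 gives 72%, the largest number among the three compounds measured so far. Compound 2 `CC/N=C(\S)NCCCCCn1nc(-c2ccccc2)ccc1=O` comes nearest; it gives 66.4%, and the step of a number 5.6 percentage points higher from compound 2 to compound 3 (within the scatter) lies within the scatter, so the two cannot be told apart. Compound 1 `C/N=C(/NC#N)NCCCn1nc(-c2ccccc2)ccc1=O` sits furthest away with 40.5%, and the steps of a number 25.9 percentage points higher from compound 1 to compound 2 (beyond the scatter) and a number 31.5 percentage points higher from compound 1 to compound 3 (beyond the scatter) are both clearly beyond the scatter.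

Compound 4 `C/N=C(\S)NCCCCn1nc(-c2ccccc2)ccc1=O` has not yet been measured. It differs from compound 3 in one place: a group of 5 heavy atoms (2 carbon, 2 nitrogen, 1 sulfur; no ring) in place of a group of 4 heavy atoms (1 carbon, 2 nitrogen, 1 sulfur; no ring), on a saturated chain carbon, four bonds along the chain from an aromatic nitrogen. Among the measured compounds shown here, the single step that bears most directly on this change is the one from compound 2 to compound 3, which also swaps a group on the same kind of chain carbon, four bonds along the chain from an aromatic nitrogen, and that step stayed within the scatter. The two large steps from compound 1 involve a different kind of group and say little about this smaller change. The expectation for compound 4 is therefore no step beyond the scatter, written as a number 3 percentage points lower from compound 3 to compound 4 (within the scatter). In this assay compound 4 is estimated to give 69%, expected to fall between 52% and 84%.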

Compound 4, a percentage reported as inhibition, in the whole organism at one dose (the size of the read-out at that dose, not a potency): 87.1%
The estimate for compound 4 lay 18.1 percentage points below the measured number; measured number above the stated range.
By their numbers in this assay, from the lowest: compound 1; then compounds 2 and 3 (each within the scatter of the next); then compound 4.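

In this assay, the place on a saturated chain carbon, four bonds along the chain from an aromatic nitrogen, proves sensitive to a small change: the group of 5 heavy atoms in place of the group of 4 gives a number 15.1 percentage points higher from compound 3 to compound 4 (beyond the scatter), so a single added carbon is enough to move the read-out clearly. Group size alone does not order these results, since the larger group of 7 heavy atoms in compound 2 stays within the scatter of the group of 4 in compound 3, while the group of 5 gives a number 20.7 percentage points higher from compound 2 to compound 4 (beyond the scatter) and so stands clear of both; compound 4 also gives a number 46.6 percentage points higher from compound 1 to compound 4 (beyond the scatter), the widest gap in this small set. No measurement shown here accounts for the rise.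

These four compounds leave open whether the best result belongs to this exact group, or whether a urea with oxygen in place of the sulfur, or a simple amine at the same place, would do as well. Each number also comes from one dose, so it gives the size of the effect at that dose and not a potency.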